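The compounds below may be only part of what the source reports. "The series", "measured", "known", "first", "only" and "open" are said of these compounds alone.

Compound 1 `CCC(C)(C)Cc1c[nH]c(CCc2ccc(-c3cccc(N)n3)cc2)n1`: 97 nM
Compound 2 `CCC(C)(C)Cc1c[nH]c(CCc2ccc(-c3ccncc3)cc2)n1`: 95 nM
Compound 3 `c1ccc(-c2ccc(CCc3nc(CC4CCCC4)c[nH]3)cc2)nc1`: 98 nM

In a functional assay on HEK293 cells for agonist activity at Bombesin receptor subtype-3 (Homo sapiens), read by luminescence and calcium flux, with a stated time of 10 min (a lower number here means that less compound is needed, a higher number that more compound is needed for the effect), compound 2 gives 95 nM, and it stands alongside compound 1 and compound 3, whose numbers lie within the usual scatter of it; none of the three is set apart from the others. Compound 4 `CCC(C)(C)Cc1c[nH]c(CCc2ccc(-c3csnn3)cc2)n1` differs from compound 2 in one place: 1,2,3-thiadiazol-4-yl in place of pyridin-4-yl on an aromatic carbon. Among the compounds with values here, the only measured step at this position is a 1.0-fold lower number from compound 1 to compound 2 (0.01 log units; within the scatter), which shows that exchanging one aromatic group for another at this carbon left the number unchanged within the scatter. Compound 3, which differs from compound 1 in two places, shows the same level as both. On this basis, replacing the six-membered ring of compound 2 with the five-membered ring of compound 4 is expected to give no step beyond the scatter, so a 1.1-fold higher number from compound 2 to compound 4 (0.02 log units; within the scatter) is the expected outcome. Compound 4 is therefore estimated at 100 nM, with a range from 45 nM to 220 nM.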

Compound 4, half-maximal effective concentration: 104 nM
For compound 4 the middle estimate is 1.0-fold (0.02 log units) below the measured one, and the stated range covers the measured number.
By their numbers in this assay, from the lowest: compounds 2, 1, 3 and 4 (each within the scatter of the next).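

In this assay, 1,2,3-thiadiazol-4-yl in place of pyridin-4-yl gives a 1.1-fold higher number from compound 2 to compound 4 (0.04 log units; within the scatter), and in place of 6-aminopyridin-2-yl it gives a 1.1-fold higher number from compound 1 to compound 4 (0.03 log units; within the scatter). The earlier compounds shown here carried only six-membered aromatic rings on this aromatic carbon, para to a large group, whereas compound 4 shows that a five-membered aromatic ring containing sulfur also stays within the scatter of both neighbours, so this position has so far tolerated a change of ring size as well as a change of ring type. No measurement at hand accounts for this flat result.

The compounds shown leave open whether a group with no aromatic ring at this carbon, such as a carboxylic acid or a morpholine, would also stay within the scatter. They also leave open whether 1,2,3-thiadiazol-4-yl would behave the same way on the core of compound 3.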